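Swapping a fluorophenyl for a fluoromethylpyridinyl ring

A few compounds are considered here, and "the series" means these few. Any claim that something is new, unique, unknown or untested is made for them only; others in the source may bear on it.

The compounds share a fused two-ring core and differ in the groups attached to it. Compound 2 `Fc1ccc(-c2cc3c(cn2)ncn3-c2ccc(OC(F)F)cc2)cc1` carries a 4-fluorophenyl and in a functional assay on HL-60 cells (Homo sapiens) for activation, read by flow cytometry, with a stated time of 4 days (on this read-out lower numbers stand for an effect already at smaller amounts and higher numbers for an effect only at larger amounts of compound), gives 10000 nM, the highest of the two numbers measured. Compound 3 `Fc1ccc(-c2cc3c(cn2)ncn3-c2ccc(OC(F)F)cc2)c(C(F)(F)F)c1` gives 1500 nM; the step of a 6.7-fold lower number from compound 2 to compound 3 (0.82 log units; beyond the scatter) shows that adding a trifluoromethyl group lowers the number beyond the scatter. Compound 1 `Cc1cc(F)ccc1-c1cc2c(cn1)ncn2CC1CC1`, with a different group on the core, sits at a limit of the assay, > 30000 nM, so no number is known for it.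

Compound 4 `Cc1nc(F)ccc1-c1cc2c(cn1)ncn2-c1ccc(OC(F)F)cc1` is the next compound, made from compound 2 by the change (6-fluoro-2-methylpyridin-3-yl in place of 4-fluorophenyl on an aromatic carbon). Among the compounds with values here, the one measured step concerns a trifluoromethyl at another place and does not bear on this exchange of one aromatic ring for another. Within the data shown here, no measured pair shows what adding a ring nitrogen and a methyl does here, so the direction of the step is open. For compound 4 a number near that of compound 2 is expected, 8000 nM, within 2000 nM to 40000 nM. The expected step of a 1.3-fold lower number from compound 2 to compound 4 (0.10 log units; within the scatter) is therefore estimated to lie within or only modestly beyond the scatter.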

Compound 4, half-maximal effective concentration: 2000 nM
Beside the measured number, compound 4's estimate is 4.0-fold (0.60 log units) above it, and the stated range covers the measured number.
By their numbers in this assay, from the lowest: compounds 3 and 4 (each within the scatter of the next); then compound 2. At a limit, above all of these: compound 1.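

In this assay the step of a 5.0-fold lower number from compound 2 to compound 4 (0.70 log units; beyond the scatter) comes with the exchange of 4-fluorophenyl for 6-fluoro-2-methylpyridin-3-yl, so the number at this place on the shared core moves when the aromatic ring itself is replaced, not only when a trifluoromethyl is added to it as in compound 3. Compound 3 and compound 4 carry different groups here, yet their values lie within the scatter of each other, which means that two different changes to compound 2 end at a similar level in this assay. Nothing shown explains why this exchange lowers the number.

As far as these compounds go, the ring nitrogen and the methyl enter together, so it stays open which of them accounts for the step, and whether an amine or a carboxylic acid in place of the ring fluorine would move the number further. Compound 1 cannot settle this, since it has a different group on the core and its > 30000 nM is a limit of the assay and not a number.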